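Difluorophenyl placement and oral exposure in the series

The source may hold more compounds than are shown below. What is called first, only, known or untested is meant among the compounds shown, and "the series" means these compounds.

Compound 1 `O=C(Nc1ccc(F)c(-c2nc3ncc(-c4ccccc4F)cc3[nH]2)c1)N1CCCC1`, compound 2 `O=C(Nc1ccc(F)c(-c2nc3ncc(-c4cc(F)ccc4F)cc3[nH]2)c1)N1CCCC1` and compound 3 `O=C(Nc1ccc(F)c(-c2nc3ncc(-c4cc(F)cc(F)c4)cc3[nH]2)c1)N1CCCC1` share one core and differ only in the fluorinated phenyl on it. In an ADME assay on the whole organism (Mus musculus, strain Swiss Webster) for pharmacokinetics, read by LC-MS, at a dose of 50 mg/kg by the oral route (on this read-out lower numbers stand for lower exposure and higher numbers for higher exposure at the dose given), compound 1 gives 2230 nM, compound 2 gives 2800 nM and compound 3 gives 4800 nM. Compound 3 therefore holds the highest of the three numbers; the steps that lead to it are a 1.7-fold higher number from compound 2 to compound 3 (0.23 log units; within the scatter) and a 2.2-fold higher number from compound 1 to compound 3 (0.33 log units; beyond the scatter). The step of a 1.3-fold higher number from compound 1 to compound 2 (0.10 log units; within the scatter) shows the fluoro addition alone making little difference.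

Compound 4 `O=C(Nc1ccc(F)c(-c2nc3ncc(-c4ccc(F)cc4F)cc3[nH]2)c1)N1CCCC1` carries the change (2,4-difluorophenyl in place of 3,5-difluorophenyl on an aromatic carbon). The steps from compound 1 and from compound 2 to compound 3 bear on this: the 2,4-difluorophenyl of compound 4 is nearer in kind to the 2-fluorophenyl of compound 1 and the 2,5-difluorophenyl of compound 2 than to the 3,5-difluorophenyl of compound 3, so a small downward step, not beyond the scatter, is expected. The estimate for compound 4 in this assay is 3200 nM, with a range of 1600 nM to 6400 nM, which means an expected step of a 1.5-fold lower number from compound 3 to compound 4 (0.18 log units; within the scatter).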

Compound 4, maximal plasma concentration: 9500 nM
The estimate for compound 4 lay 3.0-fold (0.47 log units) below the measured number; measured number above the stated range.
By their numbers in this assay, from the lowest: compounds 1, 2, 3 and 4 (each within the scatter of the next, the first and the last beyond it).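

In this assay, exchanging one difluorophenyl for the other at this place gives a 2.0-fold higher number from compound 3 to compound 4 (0.30 log units; within the scatter), so the 2,4-difluorophenyl and the 3,5-difluorophenyl are not separated on this read-out. The 2,4-difluorophenyl does separate from the 2,5-difluorophenyl, with a 3.4-fold higher number from compound 2 to compound 4 (0.53 log units; beyond the scatter), and from the 2-fluorophenyl, with a 4.3-fold higher number from compound 1 to compound 4 (0.63 log units; beyond the scatter), so with the atoms unchanged the arrangement of the two fluorines alone can move the number beyond the scatter. Going by these compounds alone, the 3,5-difluorophenyl is thus no longer the only group beyond the scatter of compound 1, and compound 2 goes against any reading based on fluorine count alone.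

No supporting data bear on the reason for these differences. As far as these compounds go, whether a 2,4-dichlorophenyl, a 2,4-dimethoxyphenyl or a pyridyl ring at this place would hold the same exposure remains open.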